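This account rests on a few compounds, and the source may have more. Where it says the series, first, only, none or still open, it means among the compounds named here.

In a functional assay on HeLa cells (Homo sapiens) for antiproliferative activity, read by sulforhodamine B assay (on this read-out lower numbers stand for stronger inhibition of growth and higher numbers for weaker inhibition of growth), compound 3 `OCCC[C@@H]1O[C@H](COCc2ccccc2)[C@@H](OCc2ccccc2)[C@H](OCc2ccccc2)[C@H]1O` gives > 50000 nM, which is a limit and not a number. Compound 1 `CC(C)C[C@@H]1O[C@H](COCc2ccccc2)[C@@H](OCc2ccccc2)[C@H](OCc2ccccc2)[C@H]1O` gives > 50000 nM, again a limit. Compound 2 `OC[C@@H]1O[C@H](COCc2ccccc2)[C@@H](OCc2ccccc2)[C@H](OCc2ccccc2)[C@H]1O` gives a true number, 25800 nM. Compound 4 `O[C@@H]1[C@@H](OCc2ccccc2)[C@H](OCc2ccccc2)[C@@H](COCc2ccccc2)O[C@H]1Cc1ccccc1` changes the same place: phenyl in place of 2-hydroxyethyl on a saturated chain carbon bound to a saturated ring carbon. The measured steps at this place offer little guidance. They are an at least 1.9-fold lower number from compound 1 to compound 2 (0.28 log units; that floor lies within the scatter) and an at least 1.9-fold higher number from compound 2 to compound 3 (0.28 log units; that floor lies within the scatter), whose floors both lie within the scatter, and a step that the two limits leave unreadable from compound 1 to compound 3, which cannot be read. No step beyond the scatter is therefore expected, in either direction. The estimated step is an at least 1.1-fold lower number from compound 3 to compound 4 (0.04 log units; that floor lies within the scatter). For compound 4 the expected value is 45000 nM, with an estimated range of 18000 nM to 100000 nM.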

Compound 4, concentration for 50% growth inhibition: 17400 nM
The estimate for compound 4 lay 2.6-fold (0.41 log units) above the measured number; measured number outside the range, below it.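

Going by these compounds alone, replacing the 2-hydroxyethyl with phenyl gives the first readable step at this position that clears the scatter: an at least 2.8-fold lower number from compound 3 to compound 4 (0.45 log units; beyond the scatter), and replacing the isopropyl does the same: an at least 2.8-fold lower number from compound 1 to compound 4 (0.45 log units; beyond the scatter). The phenyl and the hydroxy cannot be told apart here, with a 1.5-fold lower number from compound 2 to compound 4 (0.17 log units; within the scatter). The two larger steps are only floors, so their full size stays unknown: the limit of > 50000 nM in this assay, at which 2 of the 4 values shown sit.

On these data alone, what an amine or a carboxylic acid would do at this place stays open. So does whether a longer chain ending in phenyl would differ from benzyl.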